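Cytotoxicity of Chromone Cinnamamides: Anilide to Benzyl Amide

The compounds below may be only part of what the source reports. "The series", "measured", "known", "first", "only" and "open" are said of these compounds alone.

Measured so far:
- compound 1, `COc1ccc2c(=O)c(/C=C/C(=O)Nc3ccccc3)coc2c1`: 523000 nM
- compound 2, `COc1ccc2c(=O)c(/C=C/C(=O)Nc3ccc(F)cc3)coc2c1`: 743000 nM

Compound 2 is the compound from which the next step is taken. In an ADME assay on HepG2 2.2.15 cells (Homo sapiens) for cytotoxicity, read by MTT assay, with stated times of 48 h and 9 days (a lower number here means that less compound is tolerated, a higher number that more compound is tolerated), compound 2 gives 743000 nM, and compound 1 gives 523000 nM; the two differ by a 1.4-fold higher number from compound 1 to compound 2 (0.15 log units; within the scatter), so the pair cannot be told apart.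

Compound 3, `COc1ccc2c(=O)c(/C=C/C(=O)NCc3ccc(F)cc3F)coc2c1`, differs from compound 2 as follows: 2,4-difluorobenzyl in place of 4-fluorophenyl on an amide-type nitrogen. Going by the values given here, the only step measured, a 1.4-fold higher number from compound 1 to compound 2 (0.15 log units; within the scatter), also involved the group on that amide-type nitrogen and stayed within the scatter, but it only added a single fluorine, whereas the present change replaces the whole group. Among the compounds with values here, no measured step covers such a change, so the expectation rests on the one small step seen: no shift beyond the scatter is expected, giving a step of a 1.1-fold lower number from compound 2 to compound 3 (0.03 log units; within the scatter). Compound 3 is therefore estimated at 700000 nM, within 350000 nM to 1400000 nM.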

Compound 3, half-maximal cytotoxic concentration: 79300 nM
Estimate against measurement, compound 3: 8.8-fold (0.95 log units) above; the measured number lies below the stated range.
By their numbers in this assay, from the lowest: compound 3; then compounds 1 and 2 (each within the scatter of the next).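

Unlike the single fluorine added in a 1.4-fold higher number from compound 1 to compound 2 (0.15 log units; within the scatter), replacing the whole group on the amide-type nitrogen moves the number clearly in this assay: 2,4-difluorobenzyl in place of 4-fluorophenyl gives a 9.4-fold lower number from compound 2 to compound 3 (0.97 log units; beyond the scatter) and in place of phenyl gives a 6.6-fold lower number from compound 1 to compound 3 (0.82 log units; beyond the scatter), so less of compound 3 is tolerated than of either anilide. This change brings an added carbon and added fluorine together, so these steps cannot show which of the two matters. No measurement on hand bears on why the number falls.

Going by these compounds, it remains open whether a plain benzyl group, without fluorine, would give a number close to that of compound 3. On these data alone, it is also open how a longer chain, such as 2-phenylethyl, would behave on the same nitrogen.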